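From fluoro to butyl on the aromatic ring

A few compounds are considered here, and "the series" means these few. Any claim that something is new, unique, unknown or untested is made for them only; others in the source may bear on it.

compound 1 `Cc1ccc(NS(=O)(=O)c2ccc(N3CCNC3=O)cc2)cc1` gives 610 nM
compound 2 `O=C1NCCN1c1ccc(S(=O)(=O)Nc2ccc(F)cc2)cc1` gives 690 nM
compound 3 `CCCCc1ccc(NS(=O)(=O)c2ccc(N3CCNC3=O)cc2)cc1` is not yet measured

Among the compounds with values here, in a functional assay on MCF7 cells (Homo sapiens) for antiproliferative activity, read by sulforhodamine B assay, with a stated time of 48 h (on this read-out lower numbers stand for stronger inhibition and higher numbers for weaker inhibition), compound 2 stands level with compound 1, the only other measured compound, and their numbers lie within the usual scatter of each other. The change to compound 3 is butyl in place of fluoro on an aromatic carbon, para to a large group. It counts as butyl in place of fluoro on an aromatic carbon and leaves the rest of the structure untouched. Within the data shown here, one measured step bears on it, the swap of methyl for fluoro at that same place, which gave a 1.1-fold higher number from compound 1 to compound 2 (0.05 log units; within the scatter) as its result. No longer chain has been measured, so this guide is weak. On these data alone, no step beyond the scatter is expected in this assay and the direction stays open. The estimated step is a 1.4-fold lower number from compound 2 to compound 3 (0.14 log units; within the scatter) with a wide margin around it. The expected value for compound 3 is 500 nM (estimated range 150 nM to 1600 nM).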

Compound 3, half-maximal inhibitory concentration: 770 nM
Estimate against measurement, compound 3: 1.5-fold (0.19 log units) below; the range from low to high includes it.
By their numbers in this assay, from the lowest: compounds 1, 2 and 3 (each within the scatter of the next).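

In this assay, within the data shown here, putting butyl, with its 4 carbons, in place of the single fluorine gives a 1.1-fold higher number from compound 2 to compound 3 (0.05 log units; within the scatter) and so stays within the scatter, which shows that this place on the aromatic ring accepts a far longer group than the earlier compounds carried. Extending the methyl of compound 1 to butyl, counted as propyl in place of hydrogen on the chain carbon bound to the ring, gives a 1.3-fold higher number from compound 1 to compound 3 (0.10 log units; within the scatter) and also stays within the scatter, so no trend with chain length can be read from these compounds. Nothing available here explains why the numbers stay so close.

On these data alone, it remains open whether a chain longer than butyl would also stay within the scatter. An amine or a carboxylic acid at this place could behave quite differently, and the compounds shown give no guide to either.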